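Pyridyl-to-phenol swap on a retinoid-curcuminoid scaffold

A few compounds are considered here, and "the series" means these few. Any claim that something is new, unique, unknown or untested is made for them only; others in the source may bear on it.

Three compounds of this series have been run in a functional assay on LNCaP cells (Homo sapiens) for cytotoxicity, read by MTT assay, with a stated time of 72 h; on this read-out lower numbers stand for stronger inhibition and higher numbers for weaker inhibition. Compound 1 `COc1ccc(/C=C/C(O)=C/C(=O)/C=C/C2=C(C)CCCC2(C)C)cn1` carries a 6-methoxypyridin-3-yl group and gives 25100 nM, the highest of the three numbers. Compound 3 `COc1cc(/C=C/C(O)=C/C(=O)/C=C/C2=C(C)CCCC2(C)C)cc(OC)c1O` gives 6200 nM, and compound 2 `CC1=C(/C=C/C(=O)/C(=C\c2ccc(O)cc2)C(=O)/C=C/c2ccc(O)cc2)C(C)(C)CCC1` gives 4500 nM. Both of these sit well below compound 1, beyond the usual scatter, and each of them carries at least one phenolic hydroxyl where compound 1 carries none.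

Compound 4 `COc1ccc(/C=C/C(O)=C/C(=O)/C=C/C2=C(C)CCCC2(C)C)cc1O` is the next entry and has not yet been measured. Relative to compound 1 the change is 3-hydroxy-4-methoxyphenyl in place of 6-methoxypyridin-3-yl on a double-bonded chain carbon bound to a double-bonded chain carbon. The shared core, with its retinoid-type ring and the enol-dione chain, is unchanged.

Among the compounds with values here, no single-point step between measured compounds is available to anchor this exact change. The expectation therefore rests on the two phenolic compounds: compound 3 at 6200 nM and compound 2 at 4500 nM both come in far lower than compound 1. On that basis compound 4 is expected to move in the same direction, with a step of about a 3.6-fold lower number from compound 1 to compound 4 (0.55 log units; beyond the scatter), beyond the scatter. Compound 4 is estimated at 7000 nM, with a plausible range from 2500 nM to 20000 nM.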

Compound 4, half-maximal inhibitory concentration: 25900 nM
The estimate for compound 4 lay 3.7-fold (0.57 log units) below the measured number; measured number outside the range, above it.
By their numbers in this assay, from the lowest: compounds 2 and 3 (each within the scatter of the next); then compounds 1 and 4 (each within the scatter of the next).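

In this assay, the exchange on a double-bonded chain carbon bound to a double-bonded chain carbon gives a 1.0-fold higher number from compound 1 to compound 4 (0.01 log units; within the scatter): 3-hydroxy-4-methoxyphenyl, with its hydrogen-bond donor and carbon-only ring, reads the same as 6-methoxypyridin-3-yl, which has no donor and a ring with a hetero atom. A phenolic hydroxyl alone therefore does not track with a lower number here: compound 3 gives 6200 nM and compound 2 gives 4500 nM, but compound 4 carries such a hydroxyl and goes against that pattern, standing with compound 1 within the scatter. Within the data shown here, nothing measured so far accounts for this outcome.

On these data alone, it remains open which other features of compound 2 and compound 3 go with their lower numbers, such as the second methoxy group of compound 3 or the additional hydroxyphenyl-bearing arm of compound 2. As far as these compounds go, it is also open whether an amine or a carboxylic acid in place of the hydroxyl of the 3-hydroxy-4-methoxyphenyl group would shift the number in this cell assay at all.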